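A few compounds are considered here, and "the series" means these few. Any claim that something is new, unique, unknown or untested is made for them only; others in the source may bear on it.

Measured compounds:
Compound 1, `COc1ccc(Cc2nnc(NC(=O)/C(C#N)=C/c3ccccc3OS(=O)(=O)c3ccc([N+](=O)[O-])cc3)s2)cc1`: 17%
Compound 2, `COc1ccc(Cc2nnc(NC(=O)/C(C#N)=C/c3ccccc3OS(=O)(=O)c3ccccc3[N+](=O)[O-])s2)cc1`: 18%
Compound 3, `N#C/C(=C\c1ccccc1OS(=O)(=O)c1ccc([N+](=O)[O-])cc1)C(=O)Nc1nnc(Cc2cccc(F)c2)s1`: "not toxic" (no number reported)

In an ADME assay on HEK-293T cells (Homo sapiens) for inhibition, read by CCK-8 assay, with a stated time of 48 h, tested at 20 uM (a lower number here means less inhibition of growth, a higher number more inhibition of growth at the concentration tested), compound 1 gives 17% and compound 2 gives 18%. The two differ by 2-nitrophenyl in place of 4-nitrophenyl on a sulfonyl sulfur, and this change moved a number 1 percentage points higher from compound 1 to compound 2 (within the scatter). Compound 3 has a different core: 3-fluorophenyl in place of 4-methoxyphenyl on a saturated chain carbon bound to an aromatic carbon. In this assay compound 3 is reported as "not toxic" (no number reported), with no number given. Compound 4, `N#C/C(=C\c1ccccc1OS(=O)(=O)c1ccccc1[N+](=O)[O-])C(=O)Nc1nnc(Cc2cccc(F)c2)s1`, has not been measured. It differs from compound 3 by 2-nitrophenyl in place of 4-nitrophenyl on a sulfonyl sulfur, the same change seen between compound 1 and compound 2, at the same place. Since that step stayed within the scatter (a number 1 percentage points higher from compound 1 to compound 2 (within the scatter)), a similarly small step is expected here, resting on compound 3 being reported as "not toxic" (no number reported). Compound 4 is therefore estimated at 10% in this assay, between 0% and 25%.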

Compound 4, percent growth inhibition at one concentration: "not toxic" (no number reported)
Compound 4 has no reported number here; there is nothing to compare the estimate with.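

In this assay, compound 3 and compound 4 carry no numbers, so no step can be read between them, and no further data bear on this result. Going by these compounds, how far their growth inhibition lies from that of compound 1 and compound 2 stays open.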